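This account rests on a few compounds, and the source may have more. Where it says the series, first, only, none or still open, it means among the compounds named here.

Working notes on the series, varied on an amide-type nitrogen of a shared core. In a functional assay on Shh Light II cells (Mus musculus) for inhibition, read by a luciferase reporter (a higher number here means a weaker inhibitor, a lower number a stronger inhibitor), compound 1 (`O=C(Nc1ccccc1Cl)N1CCC(c2nc(-c3ccc4ccccc4n3)no2)CC1`) gives 510 nM as the reference value. Compound 2 (`O=C(NC1CCNCC1)N1CCC(c2nc(-c3ccc4ccccc4n3)no2)CC1`) gives 2500 nM in this assay and compound 3 (`CC(=O)N1CCC(NC(=O)N2CCC(c3nc(-c4ccc5ccccc5n4)no3)CC2)CC1`) gives 500 nM there too. Compound 3 stands level with compound 1, since a 1.0-fold lower number from compound 1 to compound 3 (0.01 log units; within the scatter) lies within the scatter, while a 5.0-fold lower number from compound 2 to compound 3 (0.70 log units; beyond the scatter) separates it from compound 2 beyond the scatter.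

Next is compound 4 (`COc1ccccc1NC(=O)N1CCC(c2nc(-c3ccc4ccccc4n3)no2)CC1`), with this change from compound 3: 2-methoxyphenyl in place of 1-acetylpiperidin-4-yl on an amide-type nitrogen. The nearest evidence is a 1.0-fold lower number from compound 1 to compound 3 (0.01 log units; within the scatter), where 1-acetylpiperidin-4-yl replaces 2-chlorophenyl at the same place with no change beyond the scatter. In contrast, a 4.9-fold higher number from compound 1 to compound 2 (0.69 log units; beyond the scatter) shows a modest loss with the unacetylated piperidin-4-yl, a group that compound 4 does not carry. Among the measured compounds shown here, no measured compound compares 2-methoxyphenyl directly with 2-chlorophenyl, so the range stays wide. No step beyond the scatter is expected in this assay. The expected change is a 1.1-fold lower number from compound 3 to compound 4 (0.05 log units; within the scatter) on this estimate. For compound 4 the estimated value is 450 nM, with an expected range of 150 nM to 1400 nM.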

Compound 4, half-maximal inhibitory concentration: 410 nM
Estimate against measurement, compound 4: 1.1-fold (0.04 log units) above, within the range that was stated.
By their numbers in this assay, from the lowest: compounds 4, 3 and 1 (each within the scatter of the next); then compound 2.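

In this assay, among the compounds shown here, methoxy in place of chloro on an aromatic carbon gives the first comparison of two substituted phenyl groups at this amide-type nitrogen, and the step stays within the scatter (a 1.2-fold lower number from compound 1 to compound 4 (0.09 log units; within the scatter)). For the compounds shown here, the 2-methoxyphenyl group also stands level with the non-aromatic 1-acetylpiperidin-4-yl group (a 1.2-fold lower number from compound 3 to compound 4 (0.09 log units; within the scatter)), so compounds 1, 3 and 4 read alike despite their different groups, while compound 2, with its unacetylated piperidin-4-yl, remains the one compound set apart beyond the scatter (a 6.1-fold lower number from compound 2 to compound 4 (0.79 log units; beyond the scatter)). No supporting measurement is available to explain why these groups read alike or why compound 2 differs.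

The compounds shown leave open how an unsubstituted phenyl, or a phenyl carrying a trifluoromethyl, a nitrile or a carboxylic acid, would read at this place, so the tolerance seen here rests on chloro and methoxy alone. They also leave open whether a piperidin-4-yl capped with a group other than acetyl, such as methanesulfonyl, or an open chain ending in an amine, would stand with compound 3 or with compound 2.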